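The source may hold more compounds than are shown below. What is called first, only, known or untested is meant among the compounds shown, and "the series" means these compounds.

The measured compounds, all tested in a functional assay on MCF7 cells (Homo sapiens) for cytotoxicity, read by neutral red uptake, with a stated time of 3 days; a lower number here means a stronger inhibitor, a higher number a weaker inhibitor:

compound 1, `Nc1ccc(-c2cc(=O)c3c(N)c(F)c(Br)c(F)c3o2)cc1F`, 160 nM
compound 2, `CCCCCC(=O)OCc1c(F)c(N)c2c(=O)cc(-c3ccc(N)c(F)c3)oc2c1F`, 160 nM
compound 3, `CN(C)CCCC(=O)OCc1c(F)c(N)c2c(=O)cc(-c3ccc(N)c(F)c3)oc2c1F`, 29 nM

Compound 3 stands lowest of the three numbers in this assay. Its distance from the other two is beyond the scatter, as shown by the steps of a 5.5-fold lower number from compound 1 to compound 3 (0.74 log units; beyond the scatter) and a 5.5-fold lower number from compound 2 to compound 3 (0.74 log units; beyond the scatter). By contrast the step of no change at the digits printed from compound 1 to compound 2 (within the scatter) stays within the scatter, so compound 1 and compound 2 cannot be told apart on these numbers.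

Compound 4, `NCc1c(F)c(N)c2c(=O)cc(-c3ccc(N)c(F)c3)oc2c1F`, has not yet been measured in this assay. It differs from compound 3 by amino in place of ((3-(dimethylamino)propyl)carbonyl)oxy on a saturated chain carbon bound to an aromatic carbon. Among the compounds with values here, no measured step matches this change exactly. Within the data shown here, the one step that touches the same region, a 5.5-fold lower number from compound 2 to compound 3 (0.74 log units; beyond the scatter), shows that the dimethylamino group on the ester chain went with a lower number. Compound 4 keeps an amino group at that position but loses the whole ester chain, so a modest rise toward compound 1 and compound 2 is expected, though smaller than their gap from compound 3. The expected step is a 2.1-fold higher number from compound 3 to compound 4 (0.32 log units; beyond the scatter). For compound 4 the estimate is 60 nM, with a range from 20 nM to 200 nM.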

Compound 4, half-maximal inhibitory concentration: 26 nM
Compound 4: the middle estimate sits 2.3-fold (0.36 log units) above what was measured, and the stated range covers the measured number.
By their numbers in this assay, from the lowest: compounds 4 and 3 (each within the scatter of the next); then compounds 1 and 2 (each within the scatter of the next).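

Replacing ((3-(dimethylamino)propyl)carbonyl)oxy with amino on the saturated chain carbon bound to an aromatic carbon gives a 1.1-fold lower number from compound 3 to compound 4 (0.05 log units; within the scatter), so in this assay the low number of compound 3 does not need the whole ester chain. The same aminomethyl group also stands apart from the other two groups at this position, with a 6.2-fold lower number from compound 2 to compound 4 (0.79 log units; beyond the scatter) and a 6.2-fold lower number from compound 1 to compound 4 (0.79 log units; beyond the scatter), so among these compounds the two that carry a nitrogen in this side group have the lower numbers, while the bromo of compound 1 and the (pentylcarbonyl)oxy of compound 2 do not. No supporting data explain why these groups give different numbers.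

As far as these compounds go, whether the nitrogen itself matters stays open, since a hydroxymethyl group here would be needed to compare directly with aminomethyl. An acetamide built on the amino group of compound 4 is equally untested by these numbers.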